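Swapping a Hydroxyphenyl for Thiophene on a Thiosemicarbazone

The source may hold more compounds than are shown below. What is called first, only, known or untested is meant among the compounds shown, and "the series" means these compounds.

Three compounds share one core. Compound 1 `CC1=CC[C@H](C(C)(C)N=C=S)CC1` gives "not determined" (no result reported) in a functional assay on UACC-62 cells (Homo sapiens) for inhibition, read by sulforhodamine B assay, with a stated time of 48 h; on this read-out higher numbers stand for weaker inhibition of growth and lower numbers for stronger inhibition of growth. Compound 2 `CC1=CC[C@H](C(C)(C)NC(=S)N/N=C/c2ccccc2O)CC1` gives 2800 nM in this assay, the lowest of the two numbers reported. Compound 3 `COc1cc(/C=N/NC(=S)NC(C)(C)[C@H]2CC=C(C)CC2)ccc1O` gives 14700 nM in this assay, a gap from compound 2 that lies beyond the usual scatter. Compound 4 `CC1=CC[C@H](C(C)(C)NC(=S)N/N=C/c2cccs2)CC1` has not yet been measured in this assay. It differs from compound 2 by thiophen-2-yl in place of 2-hydroxyphenyl on a carbon with a double bond to nitrogen. No change of this kind has been measured among these compounds, so no step size can be read off directly. The expected step, a 1.8-fold higher number from compound 2 to compound 4 (0.25 log units; within the scatter), is a modest weakening that may still fall within the scatter. Compound 4 is estimated at 5000 nM, with a range from 1500 nM to 20000 nM.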

Compound 4, concentration for 50% growth inhibition: 2600 nM
Estimate against measurement, compound 4: 1.9-fold (0.28 log units) above, and the stated range covers the measured number.
By their numbers in this assay, from the lowest: compounds 4 and 2 (each within the scatter of the next); then compound 3.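

In this assay, thiophen-2-yl in place of 2-hydroxyphenyl on a carbon with a double bond to nitrogen gives a 1.1-fold lower number from compound 2 to compound 4 (0.03 log units; within the scatter), so the two groups cannot be told apart here. In this pair, then, growth inhibition at this level does not depend on the hydrogen-bond donor of 2-hydroxyphenyl or on a six-membered ring at this place. Nothing on hand explains why the two groups match.

From the compounds shown here alone, what a pyridin-2-yl ring or a plain methyl group would do on this carbon remains open. So does whether any ring is needed here at all.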